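The source may hold more compounds than are shown below. What is called first, only, known or untested is meant among the compounds shown, and "the series" means these compounds.

Compound 1 `CC1CC/C(=N\Nc2ccccc2I)c2ncc(C(=O)O)c(=O)n21`: in a functional assay on the whole organism for inhibition, with Rattus norvegicus as the target (a lower number here means that less compound is needed, a higher number that more compound is needed for the effect), compound 1 gives > 1000 umol/kg, which is a limit of the assay.
Compound 2 `CC1CC/C(=N\Nc2ccccc2O)c2ncc(C(=O)O)c(=O)n21`: in this assay compound 2 gives > 100 umol/kg, also a limit.
Compound 3 `COc1ccccc1N/N=C1\CCC(C)n2c1ncc(C(=O)O)c2=O`: in this assay compound 3 gives > 1000 umol/kg, again a limit.

Compound 3 thus stands at a limit, as do both other compounds. Compound 4 `CC1CC/C(=N\Nc2ccccc2[N+](=O)[O-])c2ncc(C(=O)O)c(=O)n21` differs from compound 3 in one place: nitro in place of methoxy on an aromatic carbon. The measured steps a step that the two limits leave unreadable from compound 1 to compound 3, a step that the two limits leave unreadable from compound 2 to compound 3 and a step that the two limits leave unreadable from compound 1 to compound 2 all alter the substituent on the six-membered aromatic ring of carbon only, but none has a readable size, so they give no direction. Two values sit at the limit of > 1000 umol/kg in this assay, at which 2 of the 3 values shown sit, and one at the limit of > 100 umol/kg in this assay, at which 1 of the 3 values shown sits. The step of a number no higher from compound 3 to compound 4 (the limit leaves the size open) is therefore expected to be small. For compound 4 the expected value in this assay is 1000 umol/kg, between 300 umol/kg and 3000 umol/kg, most likely again only a limit.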

Compound 4, dose for 50% inhibition: > 1000 umol/kg
Compound 4 gave a limit, no number; the forecaster's own chance of this, stated with the estimate: 80%; the middle value sits exactly at the limit.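

Compound 4 gives only a limit, as do compound 1, compound 2 and compound 3, so none of the steps to compound 4 can be read. The compounds shown leave open whether changing this aromatic substituent alters the dose needed at all.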